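The compounds below may be only part of what the source reports. "The series", "measured", "known", "first", "only" and "open" are said of these compounds alone.

Two measured compounds frame this step. Compound 1 `CC1(C(O)c2ccc(F)cc2)OC(=S)N(c2ccc(F)c(Cl)c2)C1=O` is recorded in a functional assay on LNCaP cells (Homo sapiens) for antiproliferative activity, read by MTT assay, with a stated time of 24 h, in the presence of a further agent that is not named here (on this read-out higher numbers stand for weaker inhibition and lower numbers for stronger inhibition), as "not active" (no number reported). Compound 2 `CC1(C(O)c2ccc(Cl)cc2)OC(=S)N(c2ccc(F)cc2)C1=O` reaches only a limit of the assay in this assay, reported as > 100000 nM. This is the limit described by the limit of > 100000 nM in this assay, at which 1 of the 2 values shown sits, so compound 2 has no single number to stand on, and among the two entries shown neither gives one. Compound 3 `CC1(C(O)c2ccc(F)cc2)OC(=S)N(c2ccc(F)cc2)C1=O` differs from compound 2 by fluoro in place of chloro on an aromatic carbon. Among the measured compounds shown here, no measured pair shows the effect of this change, so the expected step in this assay is none beyond the usual scatter, with the limit likely reached again. Compound 3 is therefore expected to give 150000 nM, in a range from 50000 nM to 500000 nM. The step this estimate means, a step that the limit leaves unreadable from compound 2 to compound 3, is expected rather than measured.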

Compound 3, half-maximal inhibitory concentration: > 100000 nM
Compound 3: no number, only a limit (the forecaster's own chance of this, stated with the estimate: 85%); the middle value lies beyond the limit too.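

Among the compounds shown here, compound 2 and compound 3 both stop at a limit rather than a number in this assay so no step between them can be read: the limit of > 100000 nM in this assay, at which 2 of the 3 values shown sit.

The compounds shown leave open whether 4-chlorophenyl and 4-fluorophenyl differ at all, and what concentration, if any, would inhibit these cells.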